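The source may report more compounds than this note shows. Statements on the series, on what has been measured and on what is new or still open speak of the compounds shown alone.

Measured compounds:
compound 1 `Cc1cc(Oc2ccc(-c3ccn4c(CC5CC5)nnc4c3Cl)cc2F)ccn1` — in an assay on cells for displacement of a labelled ligand from metabotropic glutamate receptor 2 (Homo sapiens), read by scintillation counting, with a stated time of 60 min (on this read-out lower numbers stand for stronger inhibition and higher numbers for weaker inhibition), compound 1 gives 63.1 nM
compound 2 `CC(C)Nc1ccc(-c2ccn3c(CC4CC4)nnc3c2Cl)cc1F` — in this assay compound 2 gives 61.7 nM

Going by the values given here, compound 2 and compound 1 lie within the scatter of each other, the only step measured being a 1.0-fold lower number from compound 1 to compound 2 (0.01 log units; within the scatter). Compound 3 `Fc1cc(-c2ccn3c(CC4CC4)nnc3c2Cl)ccc1NC1CC1` carries cyclopropyl in place of isopropyl on a nitrogen on an aromatic ring. Among the compounds with values here, no measured step varies the group on this nitrogen, so the one step measured does not bear directly on the change; it only shows the shared core tolerating different groups at this position. The step of a 1.1-fold higher number from compound 2 to compound 3 (0.02 log units; within the scatter) is therefore expected to stay within the scatter. Compound 3 is estimated at 65 nM, range 30 nM to 140 nM.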

Compound 3, inhibition constant: 10.2 nM
Estimate against measurement, compound 3: 6.4-fold (0.80 log units) above; measured number outside the range, below it.
By their numbers in this assay, from the lowest: compound 3; then compounds 2 and 1 (each within the scatter of the next).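

On the nitrogen on an aromatic ring, the group matters in this assay: cyclopropyl in place of isopropyl gives a 6.0-fold lower number from compound 2 to compound 3 (0.78 log units; beyond the scatter) at the same heavy-atom count. The earlier pair showed no separation between isopropylamino and (2-methylpyridin-4-yl)oxy, whereas cyclopropylamino in place of (2-methylpyridin-4-yl)oxy gives a 6.2-fold lower number from compound 1 to compound 3 (0.79 log units; beyond the scatter) in the same assay. Nothing available explains why the three-membered ring gives the lower number. Open, going by these compounds, is how cyclobutyl or a plain methyl on this nitrogen would compare with cyclopropyl. Also open, on these data alone, is whether the cyclopropylamino difference persists when the cyclopropylmethyl group on the shared core is replaced by an ethyl chain.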